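Exchanging the Ring That Carries the Tetrazole

The source may hold more compounds than are shown below. What is called first, only, known or untested is meant among the compounds shown, and "the series" means these compounds.

Measured in a functional assay (Pituitary gland cell) with Rattus norvegicus as the target; a higher number here means that more compound is needed for the effect, a lower number that less compound is needed:
compound 1 `CC(C)(N)CC(=O)N[C@@H]1CCc2ccccc2N(Cc2ccc(-c3ccccc3C(=O)O)cc2)C1=O` gives 2500 nM
compound 2 `CC(C)(N)CC(=O)N[C@@H]1CCc2ccccc2N(Cc2ccc(-c3cccnc3-c3nn[nH]n3)cc2)C1=O` gives 2350 nM

Compound 2 has the lower of the two numbers, but it sits within the scatter of compound 1. Compound 3 `CC(C)(N)CC(=O)N[C@@H]1CCc2ccccc2N(Cc2ccc(-n3cccc3-c3nn[nH]n3)cc2)C1=O` differs from compound 2 in one place: 2-(2H-tetrazol-5-yl)-1H-pyrrol-1-yl in place of 2-(2H-tetrazol-5-yl)pyridin-3-yl on an aromatic carbon. Going by the values given here, only one measured step touches this region, a 1.1-fold lower number from compound 1 to compound 2 (0.03 log units; within the scatter), and it changed the number by less than the scatter. Since a larger exchange at the same place left this assay unmoved, compound 3 is expected to show no change beyond the scatter, with a 1.1-fold higher number from compound 2 to compound 3 (0.03 log units; within the scatter). The estimate for compound 3 is 2500 nM, within 1000 nM to 6000 nM.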

Compound 3, half-maximal effective concentration: 275 nM
The estimate for compound 3 lay 9.1-fold (0.96 log units) above the measured number; measured number outside the range, below it.
By their numbers in this assay, from the lowest: compound 3; then compounds 2 and 1 (each within the scatter of the next).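

In this assay this position proves sensitive after all: 2-(2H-tetrazol-5-yl)-1H-pyrrol-1-yl gives an 8.5-fold lower number from compound 2 to compound 3 (0.93 log units; beyond the scatter) and also a 9.1-fold lower number from compound 1 to compound 3 (0.96 log units; beyond the scatter) even though the earlier exchange stayed within the scatter. With the tetrazole kept, changing only the ring that carries it, from six-membered to five-membered, is enough to shift the number beyond the scatter. No measurement here explains this shift.

As far as these compounds go, it remains open whether the pyrrole ring would hold this gain with a carboxylic acid in place of the tetrazole, or with a methyl group added to the ring.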